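Ethyl removal on a tetrazolyl bicyclic core: expectation for compound 4

This account rests on a few compounds, and the source may have more. Where it says the series, first, only, none or still open, it means among the compounds named here.

Three compounds bearing a tetrazole on a fused bicyclic core have been tested in a functional assay on the whole organism (strain Sprague-Dawley) for inhibition, with Rattus norvegicus as the target; on this read-out higher numbers stand for an effect only at larger amounts of compound and lower numbers for an effect already at smaller amounts. Compound 1 `O=c1c(-c2nn[nH]n2)c[nH]c2ccccc12` gives 1.25 mg/kg in this assay. Compound 2 `CCc1cccc2cc(-c3nn[nH]n3)cnc12` gives 2.5 mg/kg, a value within the scatter of that of compound 1. For compound 3 `CCc1ccc2c(=O)c(-c3nn[nH]n3)c[nH]c2c1` this assay reports only a limit, < 5 mg/kg. The change from compound 3 to compound 1 is hydrogen in place of ethyl on an aromatic carbon, and its size, a step that the limit leaves unreadable from compound 3 to compound 1, cannot be read because of the limit of < 5 mg/kg in this assay, at which 1 of the 3 values shown sits. How the cores of compound 2 and compound 3 differ is not broken down here.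

Compound 4 `c1ccc2ncc(-c3nn[nH]n3)cc2c1` has not yet been measured. It differs from compound 2 by hydrogen in place of ethyl on an aromatic carbon; this is the same kind of change as from compound 3 to compound 1, but here the place is ortho to a fused ring and meta to a fused ring, whereas there it was meta to a fused ring and para to a fused ring. The step expected here, no change at the digits printed from compound 2 to compound 4 (within the scatter), rests on compound 1 giving 1.25 mg/kg without the ethyl and on the unreadable a step that the limit leaves unreadable from compound 3 to compound 1. Compound 4 is therefore expected to give about 2.5 mg/kg, likely between 1.25 mg/kg and 5 mg/kg.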

Compound 4, minimum effective dose: 10 mg/kg
Compound 4: middle estimate off by 4.0-fold (0.60 log units), on the low side, and the stated range ends below it.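

In this assay, hydrogen in place of ethyl on an aromatic carbon, ortho to a fused ring and meta to a fused ring, gives a 4.0-fold higher number from compound 2 to compound 4 (0.60 log units; beyond the scatter), so on this core the change has a modest but readable effect. The same kind of change from compound 3 to compound 1, made at a place meta to a fused ring and para to a fused ring, cannot be read because the step starts from a limit: the limit of < 5 mg/kg in this assay, at which 1 of the 4 values shown sits. The result therefore shows what the change does on the core of compound 2, but it does not show whether that step carries over to the core of compound 1, and a single readable pair sets no rule for the series.

On these data alone, only ethyl and hydrogen appear at this place on the core of compound 2, so it remains open whether the step depends on the ethyl itself. As far as these compounds go, what a methyl, a propyl chain or an amine would give at the same place also remains open.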